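The source may hold more compounds than are shown below. What is called first, only, known or untested is meant among the compounds shown, and "the series" means these compounds.

Working notes on the sulfone series. Compound 1 `NC[C@@H]1CCCc2cc(S(=O)(=O)c3cccc(F)c3)ccc21` is the parent amine; in an assay on isolated protein for displacement of a labelled ligand from 5-hydroxytryptamine receptor 6 (Homo sapiens) (on this read-out higher numbers stand for weaker inhibition and lower numbers for stronger inhibition), compound 1 gives 0.0794 nM. Compound 2 `O=S(=O)(c1cccc(F)c1)c1ccc2c(c1)CCC[C@H]2CN1CCCS1(=O)=O` carries a ring-bearing group on the same chain carbon, and in this assay compound 2 gives 31.6 nM. Compound 3 `CC(=O)N(C)C[C@@H]1CCCc2cc(S(=O)(=O)c3cccc(F)c3)ccc21` carries the acetyl(methyl)amino group, and in this assay compound 3 gives 1.59 nM, the second highest of the three numbers, with compound 2 nearest and compound 1 furthest. Compound 4 `CN(C[C@@H]1CCCc2cc(S(=O)(=O)c3cccc(F)c3)ccc21)S(C)(=O)=O` differs from compound 3 by methylsulfonyl in place of acetyl on an amine nitrogen. Among the compounds with values here, the steps that bear on this are a 20-fold higher number from compound 1 to compound 3 (1.30 log units; beyond the scatter) and a 20-fold lower number from compound 2 to compound 3 (1.30 log units; beyond the scatter), both large and in opposite directions; because a 20-fold lower number from compound 2 to compound 3 (1.30 log units; beyond the scatter) places the sulfonyl-containing analogue at the weak end, a moderate rise is expected for compound 4, namely a 2.5-fold higher number from compound 3 to compound 4 (0.40 log units; beyond the scatter). Compound 4 is estimated at 4 nM, range 1.2 nM to 13 nM.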

Compound 4, inhibition constant: 0.398 nM
Compound 4: the middle estimate sits 10-fold (1.00 log units) above what was measured; measured number below the stated range.
By their numbers in this assay, from the lowest: compound 1; then compound 4; then compound 3; then compound 2.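

In this assay there is a 4.0-fold lower number from compound 3 to compound 4 (0.60 log units; beyond the scatter) with methylsulfonyl in place of acetyl, so a sulfonyl group on this amine nitrogen does not by itself place a compound at the weak end of the series. The methyl(methylsulfonyl)amino group, which has no ring, shows a 79-fold lower number from compound 2 to compound 4 (1.90 log units; beyond the scatter) against the ring-bearing group and a 5.0-fold higher number from compound 1 to compound 4 (0.70 log units; beyond the scatter) against the amino group, which keeps the lowest number. No measurement shown here explains these steps.

Still open, from the compounds shown here alone, is whether a longer chain on the sulfonyl, such as ethylsulfonyl, keeps the lower number over acetyl. Also open, going by these compounds, is how a methylamino group compares with the amino group at this position.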